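Switching a halogen about the amide ring of compound 1

The source may report more compounds than this note shows. Statements on the series, on what has been measured and on what is new or still open speak of the compounds shown alone.

Compound 1, `CCN1CCN(c2cc(C)c3cc(NC(=O)c4ccccc4F)ccc3n2)CC1`, is one of three quinoline amides tested in a functional assay on SK-BR-3 cells (Homo sapiens) for antiproliferative activity, read by MTT assay, with a stated time of 72 h; a higher number here means a weaker inhibitor, a lower number a stronger inhibitor; compound 1 gives 38100 nM, the highest of the three numbers. Compound 2, `CCN1CCN(c2cc(C)c3cc(NC(=O)c4ccco4)ccc3n2)CC1`, gives 37500 nM, and compound 3, `CCN1CCN(c2cc(C)c3cc(NC(=O)c4ccc(F)c(F)c4)ccc3n2)CC1`, gives 1980 nM. The step of a 1.0-fold lower number from compound 1 to compound 2 (0.01 log units; within the scatter) shows that exchanging the ring on the carbonyl carbon for a different aromatic ring need not move the number at all, whereas the step of a 19-fold lower number from compound 1 to compound 3 (1.28 log units; beyond the scatter) shows that a change in the pattern of fluorine atoms on a phenyl ring can lower it by a large amount.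

Compound 4, `CCN1CCN(c2cc(C)c3cc(NC(=O)c4ccc(Br)cc4)ccc3n2)CC1`, carries the change (4-bromophenyl in place of 2-fluorophenyl on a carbonyl carbon). Among the measured compounds shown here, no measured step swaps one halogen for another on that ring, so the two existing steps only frame the possibilities: either no movement beyond the scatter, as from compound 1 to compound 2, or a large drop, as from compound 1 to compound 3. A bromophenyl group, like the difluorophenyl of compound 3, places its halogen away from the carbonyl attachment, which suggests some gain is plausible but far from certain. The expected step is a 4.2-fold lower number from compound 1 to compound 4 (0.63 log units; beyond the scatter), and compound 4 is estimated at 9000 nM, with a range from 1500 nM to 40000 nM.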

Compound 4, half-maximal inhibitory concentration: 6310 nM
Estimate against measurement, compound 4: 1.4-fold (0.15 log units) above, and the stated range covers the measured number.
By their numbers in this assay, from the lowest: compound 3; then compound 4; then compounds 2 and 1 (each within the scatter of the next).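

In this assay, among the compounds shown here, the step of a 6.0-fold lower number from compound 1 to compound 4 (0.78 log units; beyond the scatter) shows that a phenyl ring carrying a single halogen can lower the number beyond the scatter, a drop that the earlier compounds showed only with the two fluorines of compound 3, while the single fluorine of compound 1 remains the case that goes against any simple link between one halogen and a gain. The step of a 5.9-fold lower number from compound 2 to compound 4 (0.77 log units; beyond the scatter) is of similar size, so 4-bromophenyl also stands apart from the furan-2-yl group, although compounds 1 and 2 lie within the scatter of each other. The step of a 3.2-fold higher number from compound 3 to compound 4 (0.50 log units; beyond the scatter) then places compound 4 between those two compounds and compound 3, so this site on the carbonyl carbon now gives three levels of activity rather than two.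

No measurement shown here explains these differences. The halogen and its place on the ring both differ between compounds 1 and 4, leaving their shares of the step unresolved; 4-fluorophenyl and 2-bromophenyl groups on the same carbonyl carbon would separate the two.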